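This account rests on a few compounds, and the source may have more. Where it says the series, first, only, none or still open, it means among the compounds named here.

Compound 1 `Cc1ccc(Cn2c(=O)[nH]c3c(N)nc(-c4ncco4)cc32)cn1`: < 7 mL.min-1.g-1
Compound 2 `Cc1ccc(Cn2c(=O)[nH]c3c(N)nc(C(F)(F)F)cc32)cn1`: < 7 mL.min-1.g-1
Compound 3 `Cc1nc(Cn2c(=O)[nH]c3c(N)nc(C(F)(F)F)cc32)co1`: < 8 mL.min-1.g-1

In an in vitro ADME assay on microsomes from liver (Homo sapiens) for metabolic stability (a higher number here means faster removal of the compound, a lower number slower removal), compound 3 stands at < 8 mL.min-1.g-1, which is a limit and not a number. Compound 1 and compound 2 also sit at a limit, (the limit of < 7 mL.min-1.g-1 in this assay, at which 2 of the 3 values shown sit). Compound 4 `Nc1ccc(Cn2c(=O)[nH]c3c(N)nc(C(F)(F)F)cc32)cn1` carries 6-aminopyridin-3-yl in place of 2-methyl-1,3-oxazol-4-yl on a saturated chain carbon bound to an aromatic nitrogen. Among the measured compounds shown here, two measured steps bear on this change. The closer one, at the same place, is a step that the two limits leave unreadable from compound 2 to compound 3. The other is a step that the two limits leave unreadable from compound 1 to compound 2. Neither gives a size to carry over, so no step beyond the usual scatter is expected in this assay. The estimated step is a step that the limit leaves unreadable from compound 3 to compound 4. For compound 4 the expected value is 6 mL.min-1.g-1, with an estimated range from 3 mL.min-1.g-1 to 12 mL.min-1.g-1.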

Compound 4, intrinsic clearance in microsomes: < 7 mL.min-1.g-1
Compound 4 gave a limit, no number; the forecaster's own chance of this, stated with the estimate: 70%; the middle value is on the limit's open side.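

In this assay, among the compounds shown here, compound 4 gives < 7 mL.min-1.g-1, which is a limit and not a number, so no step to compound 2 or compound 3 can be read. The compounds shown leave open how fast each is actually removed.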